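A cyclobutyl change on compound 2

This account rests on a few compounds, and the source may have more. Where it says the series, first, only, none or still open, it means among the compounds named here.

Measured values in an in vitro ADME assay on microsomes from Gut (Homo sapiens) for metabolic stability, in the presence of a further agent that is not named here (on this read-out higher numbers stand for fast clearance and lower numbers for slow clearance), are as follows
- compound 1 `CC(C)(CO)CNC(=O)c1cc2cc(C#N)ccc2n1Cc1cc(Cl)cc(Cl)c1` gives 98 mL.min-1.g-1
- compound 2 `COc1ccc(Cl)cc1Cn1c(C(=O)NCC(C)(C)CO)cc2cc(C#N)ccc21` gives 63 mL.min-1.g-1
- compound 3 `Cc1ccc(Cl)cc1Cn1c(C(=O)NCC(C)(C)CO)cc2cc(C#N)ccc21` gives 124 mL.min-1.g-1

Compound 2, at 63 mL.min-1.g-1, cannot be separated from compound 1 or compound 3, as both its steps lie within the scatter. Compound 4 `COc1ccc(Cl)cc1Cn1c(C(=O)NCC2(CO)CCC2)cc2cc(C#N)ccc21` differs from compound 2 in one place, on a saturated chain carbon bound to an amide-type nitrogen, and the difference reads (1-(hydroxymethyl)cyclobutyl in place of 1-(hydroxymethyl)-1-methylethyl on a saturated chain carbon bound to an amide-type nitrogen). Within the data shown here, none of the measured steps touches that place. The step of a 1.6-fold lower number from compound 1 to compound 2 (0.19 log units; within the scatter), the step of a 1.3-fold higher number from compound 1 to compound 3 (0.10 log units; within the scatter) and the step of a 2.0-fold higher number from compound 2 to compound 3 (0.29 log units; within the scatter) all concern other parts of the structure, and all stay within the scatter. They therefore bear on the new change only indirectly, and the data hold no direct measure of it. No shift beyond the scatter is expected in this assay, and the expected step is a 1.2-fold higher number from compound 2 to compound 4 (0.08 log units; within the scatter). For compound 4 the estimated value is 75 mL.min-1.g-1, with an expected range from 35 mL.min-1.g-1 to 150 mL.min-1.g-1.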

Compound 4, intrinsic clearance in microsomes: 179 mL.min-1.g-1
For compound 4 the middle estimate is 2.4-fold (0.38 log units) below the measured one; the measured number lies above the stated range.
By their numbers in this assay, from the lowest: compounds 2, 1, 3 and 4 (each within the scatter of the next, the first and the last beyond it).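

In this assay, among these compounds, the change to 1-(hydroxymethyl)cyclobutyl gives a 2.8-fold higher number from compound 2 to compound 4 (0.45 log units; beyond the scatter) and is the first step to lie beyond the scatter. The three earlier steps all concerned other parts of the structure and stayed within the scatter, so only this result shows that the read-out responds to the group held on the saturated chain carbon bound to an amide-type nitrogen. Nothing available here accounts for this shift.

From the compounds shown here alone, whether the same exchange would shift the number to a similar extent on the 3,5-dichlorophenyl or 5-chloro-2-methylphenyl partners of compound 1 and compound 3 remains open. Among the compounds shown here, it is also open how a 1-(hydroxymethyl)cyclopropyl or 1-(hydroxymethyl)cyclopentyl group at this place would read, so the single step gives no trend with ring size.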